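The source may hold more compounds than are shown below. What is called first, only, known or untested is meant among the compounds shown, and "the series" means these compounds.

Compound 1 `N=C(N)c1ccc(-c2ccc(-c3cc(Cl)cc(Cl)c3)s2)cc1`: 1520 nM
Compound 2 `N=C(N)c1ccc(-c2ccc(-c3ccc(Cl)cc3)s2)cc1F`: 163 nM
Compound 3 `COc1cc(OC)cc(-c2ccc(-c3ccc(C(=N)N)c(F)c3)s2)c1`: 194 nM

In a functional assay on MDA-MB-435 cells (Homo sapiens) for inhibition, read by sulforhodamine B assay, with a stated time of 48 h (on this read-out lower numbers stand for stronger inhibition of growth and higher numbers for weaker inhibition of growth), compound 2 gives a number that compound 3 matches within the scatter, while compound 1 stands beyond the scatter at a clearly higher number. Compound 4 `N=C(N)c1ccc(-c2ccc(-c3ccccc3)s2)cc1F` has not yet been measured. It differs from compound 2 by hydrogen in place of chloro on an aromatic carbon. Within the data shown here, no pair of measured compounds shows this change, so its size cannot be read from the numbers at hand. The step of a 2.1-fold higher number from compound 2 to compound 4 (0.33 log units; beyond the scatter) is expected to be small, toward weaker inhibition of growth, and may fall within the scatter. The estimate for compound 4 is 350 nM, with a range from 120 nM to 1200 nM.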

Compound 4, concentration for 50% growth inhibition: 2180 nM
Beside the measured number, compound 4's estimate is 6.2-fold (0.79 log units) below it, outside the stated range (above it).
By their numbers in this assay, from the lowest: compounds 2 and 3 (each within the scatter of the next); then compounds 1 and 4 (each within the scatter of the next).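

In this assay, the change of 4-chlorophenyl to phenyl gives a 13-fold higher number from compound 2 to compound 4 (1.13 log units; beyond the scatter). Among these compounds, this is the first pair of measured compounds that differ in one place, and it shows that a chloro on this aromatic carbon, para to a large group, counts heavily for inhibition of growth. Nothing at hand bears on why the step is so large. As far as these compounds go, whether a bromo, a methyl or an amine at this position would keep the number of compound 2 stays open. Also open, from the compounds shown here alone, is whether the same change gives a step of this size without the fluoro of compound 2.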